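The compounds below may be only part of what the source reports. "The series", "measured", "known", "first", "only" and "open" are said of these compounds alone.

Measured so far:
Compound 1 `COc1ccc(COc2ccc(-c3nn(CCC#N)c(=O)o3)cc2)cc1` gives 16000 nM in an assay for inhibition of Amine oxidase [flavin-containing] A (Rattus norvegicus); on this read-out higher numbers stand for weaker inhibition and lower numbers for stronger inhibition.
Compound 2 `N#CCCn1nc(-c2ccc(OCc3ccc([N+](=O)[O-])cc3)cc2)oc1=O` gives 11000 nM in this assay.
Compound 3 `COc1cccc(COc2ccc(-c3nn(CCC#N)c(=S)o3)cc2)c1` gives 8100 nM in this assay.

Compound 3 gives a number that lies within the scatter of both compound 2 and compound 1, so the three numbers cannot be told apart. Compound 4 `N#CCCn1nc(-c2ccc(OCc3cccc(Cl)c3)cc2)oc1=S` differs from compound 3 in one place: chloro in place of methoxy on an aromatic carbon. Within the data shown here, the only measured step that bears on this, the swap of one group on an aromatic carbon, is a 1.5-fold lower number from compound 1 to compound 2 (0.16 log units; within the scatter), so the one comparable change left the number within the scatter. A step of similar size, not beyond the scatter, is therefore expected, a 1.2-fold lower number from compound 3 to compound 4 (0.06 log units; within the scatter). Compound 4 is expected to give 7000 nM in this assay, estimated between 2500 nM and 20000 nM.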

Compound 4, half-maximal inhibitory concentration: 11000 nM
For compound 4 the middle estimate is 1.6-fold (0.20 log units) below the measured one, within the range that was stated.
By their numbers in this assay, from the lowest: compounds 3, 2, 4 and 1 (each within the scatter of the next).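

Replacing methoxy with chloro, which turns 3-methoxyphenyl into 3-chlorophenyl, gives (a 1.4-fold higher number from compound 3 to compound 4 (0.13 log units; within the scatter)) in this assay. At this place on the ring, meta to a large group, the two groups therefore cannot be told apart, even though they differ in size and in hydrogen-bond acceptors. No measured information is available to explain this result. Going by these compounds, it remains open whether an amine or a carboxylic acid at this same place would shift the number beyond the scatter.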